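Branching the side chain on a shared core

A few compounds are considered here, and "the series" means these few. Any claim that something is new, unique, unknown or untested is made for them only; others in the source may bear on it.

The three measured compounds, in a functional assay on A549 cells (Homo sapiens) for cytotoxicity, with a stated time of 48 h; a higher number here means a weaker inhibitor, a lower number a stronger inhibitor:
Compound 1, `CCCCOc1ccc2oc(/C=C/[S+](C)[O-])cc(=O)c2c1`, gives 1400 nM.
Compound 2, `CC(C)CCOc1ccc2oc(/C=C/[S+](C)[O-])cc(=O)c2c1`, gives 1000 nM.
Compound 3, `CCC(=O)Oc1ccc2oc(/C=C/[S+](C)[O-])cc(=O)c2c1`, gives 2400 nM.

Compound 4, `CC(C)C(=O)Oc1ccc2oc(/C=C/[S+](C)[O-])cc(=O)c2c1`, has not yet been measured in this assay. It arises from compound 3 by methyl in place of hydrogen on a saturated chain carbon bound to a carbonyl carbon and a saturated chain carbon. The same kind of change has been made once before among these compounds: compound 2 arises from compound 1 by methyl in place of hydrogen on a saturated chain carbon bound to two saturated chain carbons, and that step gave a 1.4-fold lower number from compound 1 to compound 2 (0.15 log units; within the scatter). The surroundings are not identical, however: in the measured pair the methyl enters on a saturated chain carbon bound to two saturated chain carbons, whereas in compound 4 it enters on a saturated chain carbon bound to a carbonyl carbon and a saturated chain carbon. The two cores themselves differ by propanoyl in place of butyl on an oxygen on an aromatic ring, which gave a 1.7-fold higher number from compound 1 to compound 3 (0.23 log units; within the scatter). The earlier step of a 1.4-fold lower number from compound 1 to compound 2 (0.15 log units; within the scatter) stayed within the scatter. On that basis a step of similar size is expected here, a 1.2-fold lower number from compound 3 to compound 4 (0.08 log units; within the scatter). Compound 4 is therefore estimated at 2000 nM in this assay, within a range from 1000 nM to 4000 nM.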

Compound 4, half-maximal inhibitory concentration: 2400 nM
Beside the measured number, compound 4's estimate is 1.2-fold (0.08 log units) below it; the measured number falls inside the stated range.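

In this assay the methyl on the propanoyl group gives no change at the digits printed from compound 3 to compound 4 (within the scatter), and the two steps for this change agree: the same change on two cores in this assay, a 1.4-fold lower number (0.15 log units; within the scatter) from compound 1 to compound 2 and no change at the digits printed (within the scatter) from compound 3 to compound 4, 1.4-fold (0.15 log units) apart, within the scatter of two such steps. Among these compounds, this shows only that the change stays within the scatter on both cores; two such small steps cannot show that the methyl has a shared effect, nor that a larger effect would carry from one core to the other. Isopropylcarbonyl in place of the ether chains gives a 2.4-fold higher number from compound 2 to compound 4 (0.38 log units; beyond the scatter) against isopentyl but a 1.7-fold higher number from compound 1 to compound 4 (0.23 log units; within the scatter) against butyl, so only the first of these steps lies beyond the scatter.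

The compounds shown leave open whether a longer chain, an amine or a carboxylic acid on an oxygen on an aromatic ring would move the number further than these groups do. They also leave open whether the same methyl change would remain this small on a core carrying such a group.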